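The source may report more compounds than this note shows. Statements on the series, on what has been measured and on what is new or still open speak of the compounds shown alone.

Measured so far:
Compound 1, `CC(Oc1ccccc1Br)C1=NCCN1`, 10 nM
Compound 2, `CCc1ccccc1OC(C)C1=NCCN1`, 100 nM

Within the data shown here, in a functional assay on CHO cells for agonist activity at Alpha-2C adrenergic receptor (Homo sapiens) (on this read-out lower numbers stand for an effect already at smaller amounts and higher numbers for an effect only at larger amounts of compound), compound 2 gives 100 nM, the highest of the two numbers known; its nearest neighbour is compound 1, which in this assay gives 10 nM. Among the measured compounds shown here, the only measured step, a 10-fold higher number from compound 1 to compound 2 (1.00 log units; beyond the scatter), is ethyl in place of bromo on an aromatic carbon.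

Compound 3, `C=C(C)c1ccccc1OC(C)C1=NCCN1`, has not been measured. It differs from compound 2 by 1-methylethenyl in place of ethyl on an aromatic carbon. Both groups are hydrocarbon, without donors or acceptors, and the position on the ring is unchanged. For the measured compounds named here, no measured step swaps one hydrocarbon group for another at this position; the step from compound 1 to compound 2 only shows that the group on this aromatic carbon matters, and that the ethyl group gave a higher number than bromo. That step is therefore of limited bearing, and it gives no direction for a change from ethyl to 1-methylethenyl.

On this basis compound 3 is expected to stay close to compound 2, with an expected step of a 1.5-fold higher number from compound 2 to compound 3 (0.18 log units; within the scatter). The estimate for compound 3 in this assay is 150 nM, within a range of 40 nM to 600 nM.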

Compound 3, half-maximal effective concentration: 115 nM
Compound 3: middle estimate off by 1.3-fold (0.12 log units), on the high side; the measured number falls inside the stated range.
By their numbers in this assay, from the lowest: compound 1; then compounds 2 and 3 (each within the scatter of the next).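

In this assay, among these compounds, the step to 1-methylethenyl in place of ethyl on this aromatic carbon, a 1.2-fold higher number from compound 2 to compound 3 (0.06 log units; within the scatter), is the first comparison of one hydrocarbon group with another at this position, and the added carbon and the double bond outside aromatic rings bring no difference beyond the scatter. Against bromo, the step of a 12-fold higher number from compound 1 to compound 3 (1.06 log units; beyond the scatter) lies beyond the scatter, as does a 10-fold higher number from compound 1 to compound 2 (1.00 log units; beyond the scatter), so both hydrocarbon groups shown stand apart from bromo on the same side, and the difference seen earlier is no longer tied to ethyl alone. Nothing at hand explains why these two hydrocarbon groups read alike or why bromo stands apart from them.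

The compounds shown leave open how a chlorine atom, a methoxy group, an amine or a longer chain such as propyl would read on this aromatic carbon, and whether any group gives a number lower than bromo does. They also leave open whether a cyclopropyl group, a hydrocarbon that brings a ring, would stay with ethyl and 1-methylethenyl or move away from them.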